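Para-substituent swaps on the benzyl arm: methyl to phenyl

The source may report more compounds than this note shows. Statements on the series, on what has been measured and on what is new or still open speak of the compounds shown alone.

Measured in an ADME assay on cells (Peritoneal macrophage, Mus musculus, strain Balb/c) for cytotoxicity, read by resazurin assay, with a stated time of 72 h; on this read-out higher numbers stand for lower toxicity in this test and lower numbers for higher toxicity in this test:
- compound 1 `CC1(Cc2ccc(C(F)(F)F)cc2)CC(S(=O)(=O)c2ccc(F)cc2)=C(c2ccc(/C(N)=N/O)cc2)O1`: compound 1 gives 103000 nM
- compound 2 `COc1ccc(CC2(C)CC(S(=O)(=O)c3ccc(F)cc3)=C(c3ccc(/C(N)=N/O)cc3)O2)cc1`: compound 2 gives > 100000 nM, a limit of the assay and not a number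
- compound 3 `Cc1ccc(CC2(C)CC(S(=O)(=O)c3ccc(F)cc3)=C(c3ccc(/C(N)=N/O)cc3)O2)cc1`: compound 3 gives 54400 nM

Compound 3 holds the lowest of the two numbers in this assay; the nearest is compound 1, with a 1.9-fold lower number from compound 1 to compound 3 (0.28 log units; within the scatter), so the two are not separated. The step from compound 2 is an at least 1.8-fold lower number from compound 2 to compound 3 (0.26 log units; that floor lies within the scatter), its size not readable because of the limit of > 100000 nM in this assay, at which 1 of the 3 values shown sits. The step that the limit leaves unreadable from compound 1 to compound 2 is likewise unreadable.

Compound 4 `CC1(Cc2ccc(-c3ccccc3)cc2)CC(S(=O)(=O)c2ccc(F)cc2)=C(c2ccc(/C(N)=N/O)cc2)O1` differs from compound 3 by phenyl in place of methyl on an aromatic carbon. The three swaps already seen at this position all stay within the scatter or at the limit, so no reading beyond the scatter is expected in this assay for a further swap there, and a larger group gives no guide from the shown data. The expected step is a 1.4-fold lower number from compound 3 to compound 4 (0.13 log units; within the scatter). Compound 4 is estimated at 40000 nM, within 15000 nM to 100000 nM.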

Compound 4, half-maximal cytotoxic concentration: 33900 nM
Compound 4: middle estimate off by 1.2-fold (0.07 log units), on the high side, within the range that was stated.
By their numbers in this assay, from the lowest: compounds 4, 3 and 1 (each within the scatter of the next, the first and the last beyond it).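

In this assay, going by these compounds alone, phenyl on this aromatic carbon gives the first fully readable step beyond the scatter in this set: a 3.0-fold lower number from compound 1 to compound 4 (0.48 log units; beyond the scatter). Compound 2 gives > 100000 nM, a limit and not a number, so the step to phenyl from methoxy, an at least 2.9-fold lower number from compound 2 to compound 4 (0.46 log units; beyond the scatter), is only a floor because of this limit: the limit of > 100000 nM in this assay, at which 1 of the 4 values shown sits. Against methyl the change does not separate the two compounds, a 1.6-fold lower number from compound 3 to compound 4 (0.21 log units; within the scatter), so compound 3 lies within the scatter of both compound 1 and compound 4, and only the two ends of the set stand apart.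

Four compounds cannot show whether the number in this assay follows the size of the group at this position. From the compounds shown here alone, what an amine, a carboxylic acid or a longer chain would give there remains open.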